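This account rests on a few compounds, and the source may have more. Where it says the series, first, only, none or still open, it means among the compounds named here.

Measured compounds:
- compound 1 `Cc1cc(O)c(C(=O)/C=C/c2ccc(Br)cc2)c(-c2ccccc2)c1C(=O)/C=C/c1ccc(Br)cc1`: 33500 nM
- compound 2 `Cc1cc(O)c(C(=O)/C=C/c2ccc(OCc3ccccc3)cc2)c(-c2ccc(Br)cc2)c1C(=O)/C=C/c1ccc(OCc2ccccc2)cc1`: "not active" (no number reported)
- compound 3 `Cc1cc(O)c(C(=O)/C=C/c2ccc(F)cc2)c(-c2ccc(OCc3ccccc3)cc2)c1C(=O)/C=C/c1ccc(F)cc1`: 25000 nM

In a functional assay on HeLa cells (Homo sapiens) for cytotoxicity, read by MTT assay, with a stated time of 24 h (on this read-out lower numbers stand for stronger inhibition and higher numbers for weaker inhibition), compound 1 gives 33500 nM, the higher of the two numbers recorded, with compound 3 at 25000 nM standing close enough that the gap between the two lies within the scatter. For compound 2 the assay returned only the note "not active" (no number reported), so no number is known for it. The step in question leads from compound 1 to compound 4 `Cc1cc(O)c(C(=O)/C=C/c2ccc(Br)cc2)c(-c2ccc(OCc3ccccc3)cc2)c1C(=O)/C=C/c1ccc(Br)cc1`, and the change is benzyloxy in place of hydrogen on an aromatic carbon. For the measured compounds named here, no measured pair shows this exact change by itself, so its effect in this assay has to be guessed from the few numbers at hand. Since the numbers for compound 1 and compound 3 sit within the scatter of each other, no step beyond the scatter is expected, in either direction. The estimate for compound 4 in this assay is therefore 35000 nM, with a likely range from 15000 nM to 90000 nM, which means an expected step of a 1.0-fold higher number from compound 1 to compound 4 (0.02 log units; within the scatter).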

Compound 4, half-maximal inhibitory concentration: "not active" (no number reported)
Nothing numeric was reported for compound 4; there is nothing to compare the estimate with.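

In this assay, for the compounds shown here, compound 4 carries only the note "not active", without a number, so no step from compound 1 to compound 4 can be read. The compounds shown leave open what benzyloxy in place of hydrogen does on its own. No measurement shown bears on this result.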